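The compounds below may be only part of what the source reports. "The series", "measured", "known", "first", "only" and "open" are said of these compounds alone.

The measured compounds:
compound 1, `O=C1[C@@H](NS(=O)(=O)c2ccc(-c3ccccn3)s2)CCN1Cc1cc2[nH]cccc-2n1`, 8%;
compound 2, `O=C1[C@@H](NS(=O)(=O)c2ccc(-c3ccon3)s2)CCN1Cc1cc2cc[nH]cc-2n1`, 49%;
compound 3, `O=C1[C@@H](NS(=O)(=O)c2cc3ccnc(Cl)c3s2)CCN1Cc1cc2[nH]cccc-2n1`, 45%.

All three were tested in an assay on isolated protein for inhibition of coagulation factor X (Oryctolagus cuniculus), tested at 1 uM; a lower number here means less inhibition, a higher number more inhibition at the concentration tested (going by the name of the read-out). Compound 1 stands lowest of the three numbers: compound 3 sits higher by a gap beyond the usual scatter, and compound 2 sits higher still, also beyond the scatter. Compound 4, `O=C1[C@@H](NS(=O)(=O)c2ccc(-c3ccncc3)s2)CCN1Cc1cc2[nH]cccc-2n1`, has not yet been measured. It differs from compound 1 in one place: pyridin-4-yl in place of pyridin-2-yl on an aromatic carbon. The two share the same atoms, joined differently. Within the data shown here, no measured pair differs in only one place, so there is no measured step of this kind to set the size of the change. Because compound 1 gives 8% while both other compounds give more, there is room for the number to rise, yet a rearrangement of one ring could just as well leave it near where it is. A small upward step is expected, a number 10 percentage points higher from compound 1 to compound 4 (within the scatter), one that may not clear the scatter. Compound 4 is estimated at 18%, within 3% to 45%.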

Compound 4, a percentage reported as inhibition, at one concentration (the size of the read-out at that concentration, not a potency): 35%
Beside the measured number, compound 4's estimate is 17 percentage points below it; low and high end bracket the measured number.
By their numbers in this assay, from the lowest: compound 1; then compounds 4, 3 and 2 (each within the scatter of the next, the first and the last beyond it).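

Placing pyridin-4-yl instead of pyridin-2-yl on the aromatic carbon next to the ring sulfur gives the first measured one-place step in this series: in this assay the change produces a number 27 percentage points higher from compound 1 to compound 4 (beyond the scatter) for this position. The two groups have the same heavy atoms, the same kind of ring and the same counts of hydrogen-bond donors and acceptors. Moving the ring nitrogen, with nothing added or removed, is therefore enough to shift the read-out at this position.

As far as these compounds go, it remains open whether pyridin-3-yl, or a phenyl ring with no ring nitrogen, would give a number closer to that of compound 1 or that of compound 4 in this assay. The data offer no measurement that explains why the two pyridine attachments differ.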